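A few compounds are considered here, and "the series" means these few. Any claim that something is new, unique, unknown or untested is made for them only; others in the source may bear on it.

Measured compounds:
- compound 1, `Cc1ccc(C(=O)Nc2cc(-c3ccccc3)nn2-c2ccccc2)cc1C` — 20 nM
- compound 2, `O=C(Nc1cc(-c2ccccc2)nn1-c1ccccc1)c1ccncc1` — 2500 nM
- compound 3, `O=C(Nc1cc(-c2ccccc2)nn1-c1ccccc1)C1=CCCCC1` — 3300 nM

All three share one core and differ only in the group attached to the carbonyl carbon of the amide. In a functional assay on cells for positive allosteric modulation of metabotropic glutamate receptor 5 (Rattus norvegicus), read by calcium flux (a higher number here means that more compound is needed for the effect, a lower number that less compound is needed), compound 3 gives the highest number of the three. Its neighbour compound 2 sits close by: a 1.3-fold higher number from compound 2 to compound 3 (0.12 log units; within the scatter) is within the scatter, so the two cannot be ranked. Both stand far from compound 1, as a 130-fold higher number from compound 1 to compound 2 (2.10 log units; beyond the scatter) and a 170-fold higher number from compound 1 to compound 3 (2.22 log units; beyond the scatter) show.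

Compound 4, `O=C(Nc1cc(-c2ccccc2)nn1-c1ccccc1)C1CCCCC1`, is the next step: cyclohexyl in place of cyclohex-1-en-1-yl on a carbonyl carbon. For the measured compounds named here, no measured step here removes a double bond from a ring, so nothing speaks directly to this change. What the data do show is that the two groups that are not 3,4-dimethylphenyl, in compound 2 and compound 3, land in the same region, while the large steps of a 130-fold higher number from compound 1 to compound 2 (2.10 log units; beyond the scatter) and a 170-fold higher number from compound 1 to compound 3 (2.22 log units; beyond the scatter) belong only to the move away from 3,4-dimethylphenyl. A saturated ring of the same size is therefore expected to stay near compound 3, with no step beyond the scatter: a 1.1-fold higher number from compound 3 to compound 4 (0.03 log units; within the scatter). Compound 4 is estimated at 3500 nM in this assay, within a range of 1200 nM to 10000 nM.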

Compound 4, half-maximal effective concentration: > 10000 nM
Compound 4: a limit, no number; the forecaster's own chance of this, stated with the estimate: 10%; at least 2.8-fold (0.45 log units) between middle value and limit.
By their numbers in this assay, from the lowest: compound 1; then compounds 2 and 3 (each within the scatter of the next). At a limit, above all of these: compound 4.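

For compound 4 the reading is a limit of the assay, not a number: the limit of > 10000 nM in this assay, at which 1 of the 4 values shown sits. At this position, on a carbonyl carbon, losing the one double bond outside aromatic rings is enough to matter, even though both groups are six-membered carbon rings with 6 heavy atoms: an at least 3.0-fold higher number from compound 3 to compound 4 (0.48 log units; beyond the scatter). Until now only the move away from 3,4-dimethylphenyl had given steps beyond the scatter, but cyclohexyl also separates from pyridin-4-yl, an at least 4.0-fold higher number from compound 2 to compound 4 (0.60 log units; beyond the scatter), and the gap to the best compound widens, an at least 500-fold higher number from compound 1 to compound 4 (2.69 log units; beyond the scatter).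

From the compounds shown here alone, how far compound 4 lies past its limit stays unknown, so the true size of these steps is open. Also open, going by these compounds, is whether an unsubstituted phenyl or a cyclopentyl group on the same carbonyl carbon would come closer to compound 1 or stay with the others.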